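Sulfation pattern and fibroblast growth factor 2 binding

The source may report more compounds than this note shows. Statements on the series, on what has been measured and on what is new or still open speak of the compounds shown alone.

Measured compounds:
compound 1 `CC(=O)N[C@H]1[C@@H](OC[C@@H](O)[C@@H](O)[C@H](O)[C@@H](O)CNc2cccc(NC(=O)CCCCC3CCSS3)c2)O[C@H](COS(=O)(=O)O)[C@H](O)[C@@H]1O[C@@H]1O[C@H](C(=O)O)[C@@H](O)[C@H](O)[C@H]1OS(=O)(=O)O`, 23 nM
compound 2 `CC(=O)N[C@H]1[C@@H](OC[C@@H](O)[C@@H](O)[C@H](O)[C@@H](O)CNc2cccc(NC(=O)CCCCC3CCSS3)c2)O[C@H](COS(=O)(=O)O)[C@H](O)[C@@H]1O[C@@H]1O[C@H](C(=O)O)[C@@H](O)[C@H](OS(=O)(=O)O)[C@H]1O`, 147 nM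
compound 3 `CC(=O)N[C@H]1[C@@H](OC[C@@H](O)[C@@H](O)[C@H](O)[C@@H](O)CNc2cccc(NC(=O)CCCCC3CCSS3)c2)O[C@H](COS(=O)(=O)O)[C@H](OS(=O)(=O)O)[C@@H]1O[C@@H]1O[C@H](C(=O)O)[C@@H](O)[C@H](O)[C@H]1OS(=O)(=O)O`, 21 nM

In an assay on isolated protein for binding affinity to fibroblast growth factor 2 (Homo sapiens), read by surface plasmon resonance (a higher number here means weaker binding, a lower number tighter binding), compound 1 gives 23 nM and compound 3 gives 21 nM. The step between them is sulfo in place of hydrogen on an oxygen on a saturated carbon, and it reads a 1.1-fold lower number from compound 1 to compound 3 (0.04 log units; within the scatter). Compound 2 shares its atoms with compound 1 but joins them differently; the difference between the two cores is not broken down here. In this assay compound 2 gives 147 nM, the highest of the three numbers, beyond the scatter from both others.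

Compound 4 `CC(=O)N[C@H]1[C@@H](OC[C@@H](O)[C@@H](O)[C@H](O)[C@@H](O)CNc2cccc(NC(=O)CCCCC3CCSS3)c2)O[C@H](COS(=O)(=O)O)[C@H](OS(=O)(=O)O)[C@@H]1O[C@@H]1O[C@H](C(=O)O)[C@@H](O)[C@H](OS(=O)(=O)O)[C@H]1O` stands to compound 2 as compound 3 stands to compound 1: the change is sulfo in place of hydrogen on an oxygen on a saturated carbon, the same change at the same place. Because a 1.1-fold lower number from compound 1 to compound 3 (0.04 log units; within the scatter) fell within the scatter, a similarly flat step is expected here. For compound 4 the expected step reads a 1.1-fold lower number from compound 2 to compound 4 (0.04 log units; within the scatter). Compound 4 is estimated at 135 nM, between 60 nM and 300 nM.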

Compound 4, dissociation constant: 60 nM
Compound 4: the middle estimate sits 2.3-fold (0.35 log units) above what was measured; the range from low to high includes it.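

In this assay, hydroxy to sulfooxy at this place reads a 2.5-fold lower number from compound 2 to compound 4 (0.39 log units; beyond the scatter), a modest step on the core of compound 2. Set beside the same change on the other core, the two steps cannot be told apart: the same change on two cores in this assay, a 1.1-fold lower number (0.04 log units; within the scatter) from compound 1 to compound 3 and a 2.5-fold lower number (0.39 log units; beyond the scatter) from compound 2 to compound 4, 2.2-fold (0.35 log units) apart, within the scatter of two such steps. The change therefore carries from one core to the other without a detectable difference, but two pairs do not fix the size of the step or show that the core of compound 2 responds more than the core of compound 1.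

The compounds shown leave open whether a phosphate in place of the sulfooxy group would read the same way on either core. Going by these compounds, a methyl ether at this oxygen also remains open.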